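This account rests on a few compounds, and the source may have more. Where it says the series, first, only, none or still open, it means among the compounds named here.

Measured compounds:
compound 1 `O=C(Nc1cccc(-n2cc(-c3ccncc3)c(-c3ccc(Cl)c(O)c3)n2)c1)Nc1ccc(Cl)c(Cl)c1`, 1700 nM
compound 2 `COc1cc(-c2nn(-c3cccc(NC(=O)c4ccc(Cl)c(C(F)(F)F)c4)c3)cc2-c2ccncc2)ccc1Cl`, 7540 nM
compound 3 `COc1cc(-c2nn(-c3cccc(NC(=O)Nc4ccc(Cl)c(C(F)(F)F)c4)c3)cc2-c2ccncc2)ccc1Cl`, 2360 nM

In a functional assay on BT-549 cells (Homo sapiens) for inhibition, read by sulforhodamine B assay, with a stated time of 48 h (on this read-out higher numbers stand for weaker inhibition of growth and lower numbers for stronger inhibition of growth), compound 2 gives the highest of the three numbers, that is the weakest growth inhibition seen here. Compound 4 `COc1cc(-c2nn(-c3cccc(NC(=O)Nc4ccc(Cl)c(Cl)c4)c3)cc2-c2ccncc2)ccc1Cl` has not yet been measured. It differs from compound 2 in one place: (3,4-dichlorophenyl)amino in place of 4-chloro-3-(trifluoromethyl)phenyl on a carbonyl carbon.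

Within the data shown here, one measured step bears on this change. Going from the amide of compound 2 to the urea of compound 3, which keeps the same aryl group, gave a 3.2-fold lower number from compound 2 to compound 3 (0.50 log units; beyond the scatter). Compound 4 is likewise a urea, so a step of similar size and direction is expected, and the remaining question is what the dichlorophenyl in place of the chloro-trifluoromethylphenyl adds. Compound 1, a urea bearing the same dichlorophenyl on a closely related core, gives 1700 nM, close to compound 3, which suggests the two aryl groups behave alike. Compound 4 is therefore expected to show a 3.8-fold lower number from compound 2 to compound 4 (0.58 log units; beyond the scatter), with an estimated value of 2000 nM, likely between 800 nM and 5000 nM.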

Compound 4, concentration for 50% growth inhibition: 1680 nM
Beside the measured number, compound 4's estimate is 1.2-fold (0.08 log units) above it, within the range that was stated.
By their numbers in this assay, from the lowest: compounds 4, 1 and 3 (each within the scatter of the next); then compound 2.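

In this assay, putting (3,4-dichlorophenyl)amino in place of 4-chloro-3-(trifluoromethyl)phenyl on the carbonyl carbon gives a 4.5-fold lower number from compound 2 to compound 4 (0.65 log units; beyond the scatter) and so turns the amide into a urea with a different aryl ring. The aryl change alone, chloro in place of trifluoromethyl, gives a 1.4-fold lower number from compound 3 to compound 4 (0.15 log units; within the scatter) and so cannot be told apart from no change, which places the measurable gain of compound 4 with the urea and not with the second chlorine. Methyl in place of hydrogen on the oxygen gives a 1.0-fold lower number from compound 1 to compound 4 (0.01 log units; within the scatter) and likewise shows no readable difference between these two ureas.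

Still open, going by these compounds, is whether an amine or a longer chain such as ethyl on that oxygen would keep this level of growth inhibition. Nothing available here explains why the urea and the amide differ.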